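The source may report more compounds than this note shows. Statements on the series, on what has been measured and on what is new or still open speak of the compounds shown alone.

Compound 1 `CC1(C)[C@H]2CC3OB(COc4ccc5ncnc(Nc6cccc(Cl)c6)c5c4)O[C@@]3(C)[C@@H]1C2`: 540 nM
Compound 2 `OB(O)/C=C/COc1ccc2ncnc(Nc3cccc(Cl)c3)c2c1`: 680 nM

In a functional assay on A-431 cells (Homo sapiens) for cytotoxicity (a higher number here means a weaker inhibitor of growth, a lower number a stronger inhibitor of growth), compound 2 gives 680 nM, which lies within the scatter of compound 1 at 540 nM, so the two stand level. Compound 3 `OB(O)c1ccc(COc2ccc3ncnc(Nc4cccc(Cl)c4)c3c2)cc1` keeps the shared core of compound 2 and alters only what sits on a saturated chain carbon bound to an oxygen on an aromatic ring: a group of 9 heavy atoms (6 carbon, 1 boron, 2 oxygen; one six-membered aromatic ring of carbon only) in place of a group of 5 heavy atoms (2 carbon, 1 boron, 2 oxygen; no ring), on a saturated chain carbon bound to an oxygen on an aromatic ring. Neither measured compound has an aromatic ring in this boron-bearing group, so the data give no direct guide to this change. The two measured compounds carry different boron-bearing groups and still fall within the scatter of each other, so no step beyond the scatter is expected in this assay, in either direction. The estimate implies a 1.1-fold lower number from compound 2 to compound 3 (0.05 log units; within the scatter), an expected change within the scatter. For compound 3 the estimated value is 600 nM, with an expected range from 200 nM to 1800 nM.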

Compound 3, concentration for 50% growth inhibition: 1820 nM
Compound 3: middle estimate off by 3.0-fold (0.48 log units), on the low side; the measured number lies above the stated range.
By their numbers in this assay, from the lowest: compounds 1 and 2 (each within the scatter of the next); then compound 3.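

In this assay, the group on a saturated chain carbon bound to an oxygen on an aromatic ring now makes a measurable difference: the group with one six-membered aromatic ring of carbon only, in place of the group with no ring, gives a 2.7-fold higher number from compound 2 to compound 3 (0.43 log units; beyond the scatter), a modest step. Compounds 1 and 2 stood level, so this is the first separation beyond the scatter among the compounds shown, and it runs towards weaker inhibition of growth. No measurement shown bears on why this step occurs.

With a single step, the compounds shown do not separate the effect of the aromatic ring from that of the larger group. They also leave open how a carboxylic acid or an amine in place of the boron-bearing part would compare.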